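Removing the chloro substituent: a step into untested ground

The compounds below may be only part of what the source reports. "The series", "measured", "known", "first", "only" and "open" are said of these compounds alone.

Measured compounds in an assay on HEK293 cells for displacement of a labelled ligand from corticotropin-releasing factor receptor 1 (Homo sapiens), read by scintillation proximity assay, with a stated time of 2 h; on this read-out higher numbers stand for weaker inhibition and lower numbers for stronger inhibition:
compound 1 `CCCN(c1c(OC)nn2c(-c3c(OC)cc(COC)cc3OC)csc12)C1CCOCC1`: 98 nM
compound 2 `CCCN(c1c(OC)nn2c(-c3c(Cl)cc(COC)cc3OC)csc12)C1CCOCC1`: 63 nM

Compound 2 holds the lowest of the two numbers in this assay, yet the pair sits within the scatter: a 1.6-fold lower number from compound 1 to compound 2 (0.19 log units; within the scatter). So the two values show no difference that can be trusted, and swapping methoxy for chloro on that aromatic carbon left the read-out essentially unchanged.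

Compound 3 `CCCN(c1c(OC)nn2c(-c3ccc(COC)cc3OC)csc12)C1CCOCC1` goes one step further. Its change from compound 2 is hydrogen in place of chloro on an aromatic carbon: the substituent on that ring carbon is removed altogether. Among the measured compounds shown here, only the step from compound 1 to compound 2 bears on this change, and it exchanged one group for another rather than removing one, so it says little about an empty position. For the measured compounds named here, with no measured step covering removal, a modest rise in the number is expected, with a range wide enough to admit no change at all: a 2.1-fold higher number from compound 2 to compound 3 (0.31 log units; beyond the scatter). Compound 3 is estimated at 130 nM in this assay, between 45 nM and 400 nM.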

Compound 3, half-maximal inhibitory concentration in the corticotropin-releasing factor receptor 1 assay: 254 nM
Beside the measured number, compound 3's estimate is 2.0-fold (0.29 log units) below it; the measured number falls inside the stated range.
By their numbers in the corticotropin-releasing factor receptor 1 assay, from the lowest: compounds 2 and 1 (each within the scatter of the next); then compound 3.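

Among the compounds shown here, in the corticotropin-releasing factor receptor 1 assay compound 3 gives 254 nM, and emptying this ring carbon is the first change at the position to pass beyond the scatter (a 4.0-fold higher number from compound 2 to compound 3 (0.61 log units; beyond the scatter)); the same holds for the step from methoxy to hydrogen (a 2.6-fold higher number from compound 1 to compound 3 (0.41 log units; beyond the scatter)). Among these three compounds, then, chloro and methoxy on this carbon, ortho to a large group, both give a lower number than hydrogen, although the two groups cannot be told apart from each other. In a physicochemical assay for solubility, read by HPLC, in phosphate buffer, measured as kinetic solubility, tested at 10 mM (on this read-out higher numbers stand for higher solubility and lower numbers for lower solubility), compound 2 gives 6300 nM and compound 3 gives 7900 nM, and the removal of chloro stays within the scatter (a 1.3-fold higher number from compound 2 to compound 3 (0.10 log units; within the scatter)), and nothing available here accounts for the change in binding.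

Going by these compounds, whether a fluoro, methyl or nitrile group on this carbon would match chloro and methoxy remains open. So does whether an amine or a longer chain would be accepted there.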